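Carbamate ester variation on the piperazine amide series

The compounds below may be only part of what the source reports. "The series", "measured", "known", "first", "only" and "open" are said of these compounds alone.

Of the compounds shown here, three sharing one core have been read in an assay for inhibition of serine/threonine-protein kinase PAK 4 (Homo sapiens), read by FRET and Z'-LYTE, with a stated time of 60 min, tested at 0.5 uM, in the presence of a further agent that is not named here; a higher number here means a stronger effect of the compound at the concentration tested, a lower number a weaker effect. Compound 1 `CC(C)C(=O)OCOC(=O)N1CCN(C(=O)c2nc(Nc3cc(C4CC4)[nH]n3)c3cc(Cl)ccc3n2)C[C@H]1C` gives 16.4%. Compound 2 `C[C@@H]1CN(C(=O)c2nc(Nc3cc(C4CC4)[nH]n3)c3cc(Cl)ccc3n2)CCN1C(=O)OCc1ccccc1` gives 4.4%. Compound 3 `CC(OC(=O)C(C)C)OC(=O)N1CCN(C(=O)c2nc(Nc3cc(C4CC4)[nH]n3)c3cc(Cl)ccc3n2)C[C@H]1C` gives 9.4%. Compound 2 stands at the smallest of the three readings; its gap to compound 3 is within the scatter, while the step of a number 12 percentage points lower from compound 1 to compound 2 (beyond the scatter) lies beyond it. The step of a number 5 percentage points higher from compound 2 to compound 3 (within the scatter) and the step of a number 7 percentage points lower from compound 1 to compound 3 (within the scatter) both stay within the scatter.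

The next compound, compound 4 `C[C@@H]1CN(C(=O)c2nc(Nc3cc(C4CC4)[nH]n3)c3cc(Cl)ccc3n2)CCN1C(=O)OCOC(=O)C(C)(C)C`, is not yet measured. It differs from compound 2 by ((tert-butyl)carbonyl)oxy in place of phenyl on a saturated chain carbon bound to an oxygen next to a carbonyl group. The closest measured analogue is the reverse of the step of a number 12 percentage points lower from compound 1 to compound 2 (beyond the scatter), where an acyloxy group of the same kind on that carbon was exchanged for phenyl and the reading fell; the step of a number 5 percentage points higher from compound 2 to compound 3 (within the scatter), also an exchange of benzyl for an acyloxy-bearing group, moved in the same direction but not beyond the scatter. A rise of modest size, at the edge of the scatter, is therefore the expectation for this assay .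

Compound 4 is expected to give 14%, within 4% to 26%, meaning an estimated step of a number 9.6 percentage points higher from compound 2 to compound 4 (within the scatter).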

Compound 4, a percentage reported as inhibition, at one concentration (the size of the read-out at that concentration, not a potency): 0.7%
Beside the measured number, compound 4's estimate is 13.3 percentage points above it; measured number below the stated range.
By their numbers in this assay, from the lowest: compounds 4, 2, 3 and 1 (each within the scatter of the next, the first and the last beyond it).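

With ((tert-butyl)carbonyl)oxy in place of phenyl on a saturated chain carbon bound to an oxygen next to a carbonyl group, a number 3.7 percentage points lower from compound 2 to compound 4 (within the scatter) stays inside the usual scatter of this assay, so an acyloxy group on that carbon does not by itself separate a compound from the benzyl carbamate, and a number 8.7 percentage points lower from compound 3 to compound 4 (within the scatter) also stays inside the scatter. Among the compounds shown here, the one new step that clears the scatter is a number 15.7 percentage points lower from compound 1 to compound 4 (beyond the scatter), where methyl replaces hydrogen on a saturated chain carbon bound to a carbonyl carbon and two saturated chain carbons, which shows that the reading at this end of the carbamate ester depends on the acyl group itself and not only on its presence. The data at hand offer no explanation for these steps.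

Still open, going by these compounds, is whether an acetyl group, a longer chain such as hexanoyl, or a benzoyl group on the same carbon would read with compound 1 or with compound 4. All four readings come from a single concentration, so they leave open how far potency follows the same order.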